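Propyl to butyl on the amine of compound 1

The source may report more compounds than this note shows. Statements on the series, on what has been measured and on what is new or still open speak of the compounds shown alone.

Compound 1 `CCCNC(=C\C(=O)/C=C/c1ccc(O)c(OC)c1)/C=C/c1ccc(O)c(OC)c1`: > 25000 nM (a limit)
Compound 2 `CC(=O)Oc1ccc(/C=C/C(=O)/C=C(/C=C/c2ccc(OC(C)=O)cc2)NCC(C)C)cc1`: > 25000 nM (a limit)
Compound 3 `O=C(/C=C(/C=C/c1ccc(O)cc1)NC1CCCCC1)/C=C/c1ccc(O)cc1`: 11600 nM

In a functional assay on CHO-K1 cells (Cricetulus griseus) for inhibition, read by sulforhodamine B assay, with a stated time of 72 h (a higher number here means a weaker inhibitor, a lower number a stronger inhibitor), compound 1 is a limit and not a number, and it shares (the limit of > 25000 nM in this assay, at which 2 of the 3 values shown sit). Only compound 3 has a number, 11600 nM. Compound 4 `CCCCNC(=C\C(=O)/C=C/c1ccc(O)c(OC)c1)/C=C/c1ccc(O)c(OC)c1` differs from compound 1 by methyl in place of hydrogen on a saturated chain carbon, three bonds along the chain from an amine nitrogen, or propyl to butyl. For the measured compounds named here, no measured pair shows this change, so only a small step towards stronger inhibition is expected in this assay, possibly none beyond the scatter. The expected step is an at least 1.1-fold lower number from compound 1 to compound 4 (0.05 log units; that floor lies within the scatter). For compound 4 the expected value is 22000 nM, with an estimated range of 10000 nM to 40000 nM.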

Compound 4, half-maximal inhibitory concentration: 20400 nM
Compound 4: middle estimate off by 1.1-fold (0.03 log units), on the high side; the range from low to high includes it.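

In this assay, methyl in place of hydrogen on a saturated chain carbon, three bonds along the chain from an amine nitrogen, gives an at least 1.2-fold lower number from compound 1 to compound 4 (0.08 log units; that floor lies within the scatter). For the compounds shown here, compound 4 thus provides the first number on the core of compound 1, but the true size of the step remains unknown, as only a floor can be read. The limit remains common in this small set: the limit of > 25000 nM in this assay, at which 2 of the 4 values shown sit.

From the compounds shown here alone, whether a longer chain such as hexyl, or a benzyl group, on this amine would lower the number further remains open.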